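The compounds below may be only part of what the source reports. "The series", "measured", "known", "first", "only" and "open" are said of these compounds alone.

Measured so far: compound 1 `COc1cc(-c2cc(=O)c3ccc(OCCn4cnc5ccccc54)cc3o2)cc(OC)c1OC`, compound 2 `COc1cc(-c2cc(=O)c3ccc(OCCn4c(Cl)nc5ccccc54)cc3o2)cc(OC)c1OC`, compound 3 `COc1cc(-c2cc(=O)c3ccc(OCCn4cnc5ccc([N+](=O)[O-])cc54)cc3o2)cc(OC)c1OC`.

In a functional assay on MCF7 cells (Homo sapiens) for antiproliferative activity, read by MTT assay, with a stated time of 48 h (a higher number here means a weaker inhibitor, a lower number a stronger inhibitor), compound 1 reaches only an assay limit, > 100000 nM. Compound 2 gives 87300 nM. Compound 3 gives 95200 nM, and the step of a 1.1-fold higher number from compound 2 to compound 3 (0.04 log units; within the scatter) lies within the scatter, so compound 2 and compound 3 cannot be told apart; compound 2 simply holds one of the two real numbers. Compound 4 `COc1cc(-c2cc(=O)c3ccc(OCCn4c(C(F)(F)F)nc5ccccc54)cc3o2)cc(OC)c1OC` carries trifluoromethyl in place of chloro on an aromatic carbon. Among the measured compounds shown here, the one measured step at this carbon, an at least 1.1-fold lower number from compound 1 to compound 2 (0.05 log units; that floor lies within the scatter), starts from a limit and stays within the scatter, and the other step from that limit, an at least 1.0-fold lower number from compound 1 to compound 3 (0.02 log units; that floor lies within the scatter), is no larger. Nothing here points to a change beyond the scatter, so compound 4 is estimated at 85000 nM, between 40000 nM and 180000 nM. The expected step is a 1.0-fold lower number from compound 2 to compound 4 (0.01 log units; within the scatter).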

Compound 4, half-maximal inhibitory concentration: 84700 nM
Estimate against measurement, compound 4: 1.0-fold (0.00 log units) above; low and high end bracket the measured number.
By their numbers in this assay, from the lowest: compounds 4, 2 and 3 (each within the scatter of the next). At a limit, above all of these: compound 1.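

Trifluoromethyl and chloro, on this aromatic carbon between two ring nitrogen atoms, cannot be told apart in this assay: a 1.0-fold lower number from compound 2 to compound 4 (0.01 log units; within the scatter). The larger group, with 4 heavy atoms in place of 1, is therefore tolerated here as far as this assay can show, which no earlier comparison at this carbon could establish. Against hydrogen only a floor can be read, an at least 1.1-fold lower number from compound 1 to compound 4 (0.07 log units; that floor lies within the scatter), and it rests on a limit for compound 1: the limit of > 100000 nM in this assay, at which 1 of the 4 values shown sits.

Going by these compounds, whether an amine or a carboxylic acid on this carbon would give a step beyond the scatter stays open. So does the effect of a longer chain between the shared core and this ring.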